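Side-chain swap on the shared core: compound 2 to compound 3

This account rests on a few compounds, and the source may have more. Where it says the series, first, only, none or still open, it means among the compounds named here.

Within the data shown here, compound 2 `O=C(O)CC[C@H](NC(=O)CN(c1nc(Cl)nc2[nH]cnc12)C1CC1)C(=O)O` stands highest of the two numbers so far in a functional assay on the whole organism (Tail, strain ICR) with Mus musculus as the target, in the tail flick test, with a stated time of 120 min, at a dose of 25 umol/kg by the oral route (on this read-out lower numbers stand for a weaker effect and higher numbers for a stronger effect at the one dose given), where compound 2 gives 30.1%. Among the measured compounds shown here, its nearest neighbour, compound 1 `N=C(N)NCCC[C@H](NC(=O)CN(c1nc(Cl)nc2[nH]cnc12)C1CC1)C(=O)O`, gives 17% in this assay, and the single measured step, a number 13.1 percentage points higher from compound 1 to compound 2 (beyond the scatter), is the only one that bears on the present question. Compound 3 `NCCCC[C@H](NC(=O)CN(c1nc(Cl)nc2[nH]cnc12)C1CC1)C(=O)O` differs from compound 2 by 2-aminoethyl in place of carboxy on a saturated chain carbon, three bonds along the chain from an amide-type nitrogen and a carbonyl carbon. For the measured compounds named here, the change undoes part of what distinguished compound 2 from compound 1, and since that earlier step was modest and upward, the expectation is a modest step the other way, a number 10.1 percentage points lower from compound 2 to compound 3 (beyond the scatter), though no step of exactly this kind has been measured, so the range is kept wide. Compound 3 is therefore expected to give about 20% in this assay, within 8% to 34%.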

Compound 3, a percentage reported as activity, at one dose (the size of the read-out at that dose, not a potency): 16.4%
The estimate for compound 3 lay 3.6 percentage points above the measured number, within the range that was stated.
By their numbers in this assay, from the lowest: compounds 3 and 1 (each within the scatter of the next); then compound 2.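

Notes on the side chain: in this assay, 2-aminoethyl in place of carboxy gives a number 13.7 percentage points lower from compound 2 to compound 3 (beyond the scatter) as a step beyond the scatter, so the higher number of compound 2 is lost with this change as well as with the side chain of compound 1. The two side chains ending in nitrogen groups do not separate, with a number 0.6 percentage points lower from compound 1 to compound 3 (within the scatter) as a step within the scatter, and among the three compounds only the 2-carboxyethyl chain of compound 2 stands apart. Nothing at hand explains this difference.

Open, as far as these compounds go, is whether the carboxylic acid itself matters or only the absence of an amine, which a primary amide or a plain butyl chain at this position would separate. Also open, from the compounds shown here alone, is how a shorter carboxymethyl chain or a longer carboxylic acid chain would read.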